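The compounds below may be only part of what the source reports. "The series", "measured", "known", "first", "only" and "open" are said of these compounds alone.

Working notes on the series.

Three analogues of the shared core have been measured in a functional assay on KBVIN cells (Homo sapiens) for antiproliferative activity, read by sulforhodamine B assay, with a stated time of 3 days; a higher number here means that more compound is needed for the effect, a lower number that less compound is needed. Compound 1 `CCC1=C(O)c2c(oc(-c3ccc(C)cc3)cc2=O)C(CC)(CC)C1=O` gives 0.08 uM. Compound 2 `CCC1=C(O)c2c(oc(-c3ccc(C)cc3C)cc2=O)C(CC)(CC)C1=O` gives 8.52 uM. Compound 3 `CCC1=C(O)c2c(oc(-c3ccc(OC)c(C)c3)cc2=O)C(CC)(CC)C1=O` gives 0.1 uM. Compound 4 `CCC1=C(O)c2c(oc(-c3ccc(OC)c(C)c3C)cc2=O)C(CC)(CC)C1=O` has not yet been measured in this assay.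

The difference between the cores of compound 1 and compound 3 is 4-methoxy-3-methylphenyl in place of 4-methylphenyl on an aromatic carbon; in this assay the result is a 1.3-fold higher number from compound 1 to compound 3 (0.10 log units; within the scatter), so the two numbers are not distinguished here. The step from compound 2 to compound 3 is an 85-fold lower number from compound 2 to compound 3 (1.93 log units; beyond the scatter).

The change from compound 1 to compound 2 is methyl in place of hydrogen on an aromatic carbon, and it made a step of a 110-fold higher number from compound 1 to compound 2 (2.03 log units; beyond the scatter). The change from compound 3 to compound 4 is methyl in place of hydrogen on an aromatic carbon. The kind of change is the same, but the surroundings differ: in compound 2 the entering methyl is meta to a methyl group, while in compound 4 it is ortho to a methyl group and meta to a methoxy group. It is therefore the same kind of change, not the same change.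

On the strength of the one measured case, the step from compound 3 to compound 4 is expected to be an 80-fold higher number from compound 3 to compound 4 (1.90 log units; beyond the scatter), resting on compound 1 to compound 2 having shown a 110-fold higher number from compound 1 to compound 2 (2.03 log units; beyond the scatter), with the surroundings of the new methyl being different enough to leave the size uncertain. Compound 4 is accordingly estimated at 8 uM, with a plausible range from 1.5 uM to 40 uM.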

Compound 4, concentration for half-maximal effect: 0.28 uM
Compound 4: the middle estimate sits 29-fold (1.46 log units) above what was measured, outside the stated range (below it).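

In this assay, methyl in place of hydrogen on an aromatic carbon again moves the number upward on the second core, the new step being a 2.8-fold higher number from compound 3 to compound 4 (0.45 log units; beyond the scatter), so the direction holds across the two pairs while the size does not. The change therefore cannot be carried from one core to another in this series as a fixed increment, as the two steps differ clearly in size: the same change on two cores in this assay, a 110-fold higher number (2.03 log units; beyond the scatter) from compound 1 to compound 2 and a 2.8-fold higher number (0.45 log units; beyond the scatter) from compound 3 to compound 4, 38-fold (1.58 log units) apart, beyond the scatter of two such steps. Two pairs show only that the surroundings of the entering methyl can matter, and they do not show which feature of those surroundings sets the size, since the entering methyl in compound 4 stands both ortho to a methyl group and meta to a methoxy group, and they give no general rule for other cores.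

The compounds shown leave open whether an ethyl group or a longer chain at the same aromatic carbon would follow the methyl step on either core, and whether a chlorine atom, an amine or a carboxylic acid there would behave differently. They also leave open how the step would look on a core carrying a hydroxyl or an ethoxy group in place of the methoxy group of compound 4.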